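A few compounds are considered here, and "the series" means these few. Any claim that something is new, unique, unknown or untested is made for them only; others in the source may bear on it.

Compound 1 `Cc1cccc(-n2nncc2CN2C(=O)C3(C(C#N)=C(N)Oc4c(N)cc5nc6ccccc6nc5c43)c3ccccc32)c1` gives 12300 nM in a functional assay on A549 cells (Homo sapiens) for antiproliferative activity, read by MTT assay, with a stated time of 48 h; a higher number here means a weaker inhibitor, a lower number a stronger inhibitor. Compound 2 `N#CC1=C(N)Oc2c(N)cc3nc4ccccc4nc3c2C12C(=O)N(Cc1cnnn1-c1ccc(F)cc1)c1ccccc12` reaches only a limit of this assay, > 50000 nM. Compound 3 `N#CC1=C(N)Oc2c(N)cc3nc4ccccc4nc3c2C12C(=O)N(Cc1cnnn1-c1ccc(Cl)cc1)c1ccccc12` likewise reaches only a limit, > 50000 nM.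

Compound 3 thus stands at the weak end of what has been measured: no number exists for it, only a limit, and it shares that limit with compound 2 (the limit of > 50000 nM in this assay, at which 2 of the 3 values shown sit). Compound 4 `N#CC1=C(N)Oc2c(N)cc3nc4ccccc4nc3c2C12C(=O)N(Cc1cnnn1-c1cccc(Br)c1)c1ccccc12` has not yet been measured. It differs from compound 3 in one place: 3-bromophenyl in place of 4-chlorophenyl on an aromatic nitrogen.

Among the measured compounds shown here, two measured steps touch this position. Replacing the 3-methylphenyl of compound 1 with a 4-fluorophenyl gave an at least 4.0-fold higher number from compound 1 to compound 2 (0.60 log units; beyond the scatter), and replacing it with a 4-chlorophenyl gave an at least 4.0-fold higher number from compound 1 to compound 3 (0.60 log units; beyond the scatter). The step that the two limits leave unreadable from compound 2 to compound 3, since both values are limits. Compound 4 carries a halogen as compounds 2 and 3 do, but as a 3-bromophenyl, matching the substitution pattern of the 3-methylphenyl of compound 1. The data do not show whether the pattern or the halogen drives the loss of activity.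

Compound 4 is therefore expected to land between the two cases, with an at least 1.6-fold lower number from compound 3 to compound 4 (0.22 log units; that floor lies within the scatter) a plausible outcome. The estimate for compound 4 is 30000 nM, with a range from 8000 nM to 60000 nM, and a real chance that only a limit is reported.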

Compound 4, half-maximal inhibitory concentration: 18900 nM
Compound 4: the middle estimate sits 1.6-fold (0.20 log units) above what was measured; measured number inside the range.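

Moving from the 4-substituted halogen compounds to the 3-bromophenyl gives an at least 2.6-fold lower number from compound 3 to compound 4 (0.42 log units; beyond the scatter) and an at least 2.6-fold lower number from compound 2 to compound 4 (0.42 log units; beyond the scatter), so a halogen on this phenyl ring does not by itself push a compound to the limit in this assay. Bromo in place of methyl then gives a 1.5-fold higher number from compound 1 to compound 4 (0.19 log units; within the scatter), meaning that the 3-bromophenyl and the 3-methylphenyl cannot be told apart here. Among these four compounds, the 3-methylphenyl and 3-bromophenyl give numbers while the 4-fluorophenyl and 4-chlorophenyl do not, with no compound going against this split, and the gain can be given only as a floor because the other two compounds have no number: the limit of > 50000 nM in this assay, at which 2 of the 4 values shown sit.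

Compound 4 differs from compound 3 in both the halogen and its place on the ring, so the compounds shown cannot say which of the two changes matters. As far as these compounds go, how this ring would behave carrying an amine, a methoxy group or a carboxylic acid also remains open.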